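Two Level Compounds and a Rearranged Third

The source may hold more compounds than are shown below. What is called first, only, known or untested is meant among the compounds shown, and "the series" means these compounds.

For the measured compounds named here, in a functional assay, with a stated time of 16 h (on this read-out higher numbers stand for weaker inhibition and lower numbers for stronger inhibition), compound 1 (`CC(C)=NNc1nc(-c2cccc([N+](=O)[O-])c2)cs1`) gives 1070000 nM and compound 2 (`C/C(CC(C)C)=N/Nc1nc(-c2cccc([N+](=O)[O-])c2)cs1`) gives 1050000 nM, so compound 2 stands level with the only other measured compound. Going by the values given here, the one measured step, a 1.0-fold lower number from compound 1 to compound 2 (0.01 log units; within the scatter), places isopropyl in place of hydrogen on a saturated chain carbon bound to a carbon with a double bond to nitrogen, and it stays within the scatter. Compound 3 (`CCC/C(CC)=N\Nc1nc(-c2cccc([N+](=O)[O-])c2)cs1`) has the same atoms as compound 2, joined differently, with a group of 7 heavy atoms (6 carbon, 1 nitrogen; no ring) in place of a group of 7 heavy atoms (6 carbon, 1 nitrogen; no ring), on a nitrogen on an aromatic ring. Among the compounds with values here, no measured step tests such a rearrangement directly, so that single step is the only guide, and it suggests no change beyond the scatter in this assay. The expected outcome is a 1.1-fold lower number from compound 2 to compound 3 (0.02 log units; within the scatter), with no clear direction. The estimated value for compound 3 is 1000000 nM, within an expected range of 400000 nM to 2200000 nM.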

Compound 3, half-maximal inhibitory concentration: 1040000 nM
For compound 3 the middle estimate is 1.0-fold (0.02 log units) below the measured one; the range from low to high includes it.
By their numbers in this assay, from the lowest: compounds 3, 2 and 1 (each within the scatter of the next).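

The new step shows that the position tolerates a rearrangement as well as an added branch: moving the same atoms around within the group of 7 heavy atoms, on a nitrogen on an aromatic ring, gives a 1.0-fold lower number from compound 2 to compound 3 (0.00 log units; within the scatter) in this assay. Measured against the smaller group in compound 1, the rearranged group gives a 1.0-fold lower number from compound 1 to compound 3 (0.01 log units; within the scatter), so all three compounds now sit within the scatter of one another, whichever of the two groups of 7 heavy atoms is present. Nothing available explains why these numbers stay level.

All the groups shown here are uncharged open carbon chains joined through the double bond to nitrogen. As far as these compounds go, whether a cyclohexyl ring, an amine or a carboxylic acid at this place would move the number remains open, as does the effect of a much longer chain.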